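Two weak cytotoxic thioureas compared on the same cells

A few compounds are considered here, and "the series" means these few. Any claim that something is new, unique, unknown or untested is made for them only; others in the source may bear on it.

Compound 2 (`O=C(c1cc(Oc2cccc(NC(=S)Nc3ccc(Cl)c(C(F)(F)F)c3)c2)ccn1)N1CCCC1`) was tested in a functional assay on HCT-116 cells (Homo sapiens) for cytotoxicity, read by MTT assay, with a stated time of 48 h (a lower number here means a stronger inhibitor, a higher number a weaker inhibitor), and gives 22400 nM. Compound 1 (`O=C(NCc1ccccc1)c1cc(Oc2cccc(NC(=S)Nc3ccc(Cl)cc3)c2)ccn1`) gives 16500 nM in this assay; the two values lie within the usual scatter of each other, so neither can be called the stronger. Compound 3 (`O=C(c1cc(Oc2cccc(NC(=S)Nc3ccc(OC(F)(F)F)cc3)c2)ccn1)N1CCCC1`) has not yet been measured. It differs from compound 2 by 4-(trifluoromethoxy)phenyl in place of 4-chloro-3-(trifluoromethyl)phenyl on an amide-type nitrogen. For the measured compounds named here, no measured pair shows what such a swap does here, so the expected step is a 1.1-fold higher number from compound 2 to compound 3 (0.03 log units; within the scatter), no larger than the scatter and in no firm direction. Compound 3 is therefore estimated at 24000 nM, with a range from 9000 nM to 60000 nM.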

Compound 3, half-maximal inhibitory concentration: 17800 nM
Compound 3: the middle estimate sits 1.3-fold (0.13 log units) above what was measured; low and high end bracket the measured number.
By their numbers in this assay, from the lowest: compounds 1, 3 and 2 (each within the scatter of the next).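

In this assay the swap gives a 1.3-fold lower number from compound 2 to compound 3 (0.10 log units; within the scatter) when 4-(trifluoromethoxy)phenyl replaces 4-chloro-3-(trifluoromethyl)phenyl on the amide-type nitrogen. This single-place comparison shows that these two aryl groups cannot be told apart here, although the entering group carries oxygen and a hydrogen-bond acceptor and lacks chlorine. No measurement on hand offers an explanation for this result.

From the compounds shown here alone, whether a carboxylic acid or an aminoethyl chain on that aryl ring would shift the number beyond the scatter remains open. Compound 1 differs from compound 2 and compound 3 in more than one place, so those steps cannot be read.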